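Fluoro for Methyl on the Lead Amine Compound

The source may hold more compounds than are shown below. What is called first, only, known or untested is meant among the compounds shown, and "the series" means these compounds.

Compound 1 `Cc1ccc(/C=C/C(=O)Oc2ccc(/C=C3\CCCCC3=O)cc2)cc1` reads 202000 nM in a functional assay on L1210 cells (Mus musculus) (a lower number here means a stronger inhibitor, a higher number a weaker inhibitor), and serves as the reference here. Compound 2 `O=C(/C=C/c1ccc(F)cc1)Oc1ccc(/C=C2\CCCCC2=O)cc1` carries fluoro in place of methyl on an aromatic carbon and reads 30900 nM in the same measurement. That swap amounts to a 6.5-fold lower number from compound 1 to compound 2 (0.82 log units; beyond the scatter) and counts as a modest change. Compound 3 `Cc1ccc(/C=C/C(=O)Oc2ccc(/C=C3\CCCC(CN(C)C)C3=O)cc2)cc1` keeps the methyl but has (dimethylamino)methyl in place of hydrogen on a saturated ring carbon, and this brings an 83-fold lower number from compound 1 to compound 3 (1.92 log units; beyond the scatter) which counts as large. Compound 3 reads 2430 nM and so holds the lowest of the three numbers.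

Compound 4 `CN(C)CC1CCC/C(=C\c2ccc(OC(=O)/C=C/c3ccc(F)cc3)cc2)C1=O` has not yet been measured. It differs from compound 3 by fluoro in place of methyl on an aromatic carbon in one place: fluoro in place of methyl on an aromatic carbon, para to a large group. Among the compounds with values here, the one measured step that bears on this is the same swap, seen as a 6.5-fold lower number from compound 1 to compound 2 (0.82 log units; beyond the scatter) without the (dimethylamino)methyl group. Within the data shown here, no measured pair shows whether that swap carries over in full once this group is present. The expected step is a 3.5-fold lower number from compound 3 to compound 4 (0.54 log units; beyond the scatter) and thus toward a lower number, somewhat smaller than the measured swap. In this assay the estimated value for compound 4 is 700 nM with an expected range from 200 nM to 2500 nM as a working figure.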

Compound 4, half-maximal inhibitory concentration: 1840 nM
Compound 4: the middle estimate sits 2.6-fold (0.42 log units) below what was measured; the range from low to high includes it.
By their numbers in this assay, from the lowest: compounds 4 and 3 (each within the scatter of the next); then compound 2; then compound 1.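

In this assay, the fluoro for methyl swap on the aromatic carbon no longer makes a clear difference once the (dimethylamino)methyl group is present, with a 1.3-fold lower number from compound 3 to compound 4 (0.12 log units; within the scatter), so the drop seen without that group does not carry over: the same change on two cores in this assay, a 6.5-fold lower number (0.82 log units; beyond the scatter) from compound 1 to compound 2 and a 1.3-fold lower number (0.12 log units; within the scatter) from compound 3 to compound 4, 4.9-fold (0.69 log units) apart, beyond the scatter of two such steps

Read the other way, adding the (dimethylamino)methyl group still counts on the fluoro compound, with a 17-fold lower number from compound 2 to compound 4 (1.23 log units; beyond the scatter), but the step is smaller than on the methyl compound: the same change on two cores in this assay, an 83-fold lower number (1.92 log units; beyond the scatter) from compound 1 to compound 3 and a 17-fold lower number (1.23 log units; beyond the scatter) from compound 2 to compound 4, 4.9-fold (0.69 log units) apart, beyond the scatter of two such steps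

Across these four compounds the two changes therefore do not simply add up, since the size of each step differs with what stands at the other place, and on the (dimethylamino)methyl core methyl and fluoro cannot be told apart.

Going by these compounds, it stays open whether chloro, methoxy or plain hydrogen on that aromatic carbon would also read the same as methyl and fluoro when the (dimethylamino)methyl group is present. Equally open is whether a diethylamino or morpholino group in place of the dimethylamino part would shrink the fluoro swap in the same way, or whether this holds only for the one amine shown.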